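A few compounds are considered here, and "the series" means these few. Any claim that something is new, unique, unknown or untested is made for them only; others in the source may bear on it.

In a functional assay on the whole organism for antagonist activity, with Mus musculus as the target, in the maximal electroshock model (on this read-out higher numbers stand for an effect only at larger amounts of compound and lower numbers for an effect already at smaller amounts), compound 1 `Cn1c(-c2cccc(F)c2)nnc1S(C)(=O)=O` gives > 200 mg/kg, which is a limit of the assay and not a number. Compound 2 `Cn1c(-c2ccccc2)nnc1S(C)(=O)=O`, with hydrogen in place of fluoro, gives > 200 mg/kg, and this too is a limit. The measured evidence therefore comes down to the limit of > 200 mg/kg in this assay, at which 2 of the 2 values shown sit. Among the measured compounds shown here, the only measured step, a step that the two limits leave unreadable from compound 1 to compound 2, has no readable size and concerns a different place on the molecule.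

Compound 3 `CSc1nnc(-c2cccc(F)c2)n1C` keeps the rest of compound 1 and changes one group: methylsulfanyl in place of methylsulfonyl on an aromatic carbon. For the measured compounds named here, no measured step touches this group, so this assay offers no size to carry over. A reported number for compound 3 would have to mean an effect at smaller amounts, and this direction is tentatively expected. The expected change is an at least 2.0-fold lower number from compound 1 to compound 3 (0.30 log units; that floor lies within the scatter), a rough estimate. For compound 3 the estimated dose is 100 mg/kg, with an expected range from 30 mg/kg to 300 mg/kg.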

Compound 3, dose for half-maximal effect: > 200 mg/kg
Compound 3 gave a limit, no number (the forecaster's own chance of this, stated with the estimate: 45%); middle value at least 2.0-fold (0.30 log units) from the limit.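

Compound 3 gives a limit and not a number in this assay, as does compound 1, so no step can be read between compound 1 and compound 3. The compounds shown leave open what dose of any of them would give a half-maximal effect: the limit of > 200 mg/kg in this assay, at which 3 of the 3 values shown sit.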